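Dropping the Acid-Bearing Amine from the Shared Core

The compounds below may be only part of what the source reports. "The series", "measured", "known", "first", "only" and "open" are said of these compounds alone.

Compound 1 `CC1=CCC[C@H]2[C@](C)(CC3=CC(=O)C=C(NCCC(=O)O)C3=O)[C@@H](C)CC[C@]12C` carries a (2-carboxyethyl)amino group on the shared core. In a functional assay on A549 cells (Homo sapiens) for cytotoxicity, read by MTT assay, with a stated time of 72 h (a higher number here means a weaker inhibitor, a lower number a stronger inhibitor), compound 1 gives 26900 nM, the lowest of the two numbers shown. Compound 3 `CC(C)(C)C1=CC(=O)C=CC1=O` gives 47000 nM in this assay, a gap from compound 1 that lies within the scatter. Compound 2 `CC(C)(C)C1=CC(=O)C=C(NCC(=O)O)C1=O` sits only at a limit in this assay, > 200000 nM, as noted in the limit of > 200000 nM in this assay, at which 1 of the 3 values shown sits. Among the compounds with values here, the single comparable step, an at least 4.2-fold lower number from compound 2 to compound 3 (0.62 log units; beyond the scatter), removes a related amino acid group and moves toward a lower number. Compound 4 `CC1=CCC[C@H]2[C@](C)(CC3=CC(=O)C=CC3=O)[C@@H](C)CC[C@]12C` differs from compound 1 by hydrogen in place of (2-carboxyethyl)amino on a double-bonded ring carbon. A modest shift to a lower number in this assay is therefore expected, the step of a 2.2-fold lower number from compound 1 to compound 4 (0.35 log units; beyond the scatter) being the estimate. Compound 4 is expected to give 12000 nM, between 4000 nM and 40000 nM.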

Compound 4, half-maximal inhibitory concentration: 30000 nM
For compound 4 the middle estimate is 2.5-fold (0.40 log units) below the measured one; low and high end bracket the measured number.
By their numbers in this assay, from the lowest: compounds 1, 4 and 3 (each within the scatter of the next). At a limit, above all of these: compound 2.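

The step of a 1.1-fold higher number from compound 1 to compound 4 (0.05 log units; within the scatter) in this assay lies within the scatter, so on this double-bonded ring carbon of the shared core, compounds with (2-carboxyethyl)amino and with hydrogen cannot be told apart. The related step of an at least 4.2-fold lower number from compound 2 to compound 3 (0.62 log units; beyond the scatter) lay beyond the scatter, so the two replacements do not read alike. Nothing shown gives a reason for this difference.

On these data alone, whether a simple amine, or a carboxylic acid on a longer chain, at this carbon would read the same on the shared core stays open.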